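The source may hold more compounds than are shown below. What is called first, only, known or untested is meant among the compounds shown, and "the series" means these compounds.

Measured so far:
Compound 1, `Cc1n[nH]cc1-c1cccc2c1CCC2c1ncc[nH]1`, gives 3 nM in a functional assay on CHO cells for agonist activity at Alpha-1A adrenergic receptor (Homo sapiens), read by FLIPR and calcium flux; a higher number here means that more compound is needed for the effect, a lower number that less compound is needed.
Compound 2, `COc1c(C)ccc2c1CCC2c1ncc[nH]1`, gives 167 nM in this assay.

Among these two numbers, compound 2 stands at the higher end: it needs the larger amount of compound for the effect, and the gap to compound 1 lies well beyond the usual scatter of repeated measurements. The two structures differ in more than one place, so nothing can be said about which change carries that gap.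

The next compound, compound 3, `COc1cccc2c1CCC2c1ncc[nH]1`, comes from compound 2 by one change only: hydrogen in place of methyl on an aromatic carbon of the fused ring system, at the position ortho to a methoxy group. Among the measured compounds shown here, no measured pair in this small set shows the effect of removing such a methyl, so the size of the step has no precedent here. Loss of one small carbon group is expected to move the number only a little, perhaps toward a slightly higher value, and quite possibly within the scatter.

Compound 3 is therefore expected to give about 220 nM in this assay, with a likely range from 60 nM to 800 nM. This corresponds to an expected step of a 1.3-fold higher number from compound 2 to compound 3 (0.12 log units; within the scatter), modest in size.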

Compound 3, half-maximal effective concentration: 32 nM
For compound 3 the middle estimate is 6.9-fold (0.84 log units) above the measured one; the whole stated range lies above it.
By their numbers in this assay, from the lowest: compound 1; then compound 3; then compound 2.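

In this assay, the aromatic carbon ortho to a methoxy group proves sensitive to even the smallest change: replacing methyl with hydrogen there gives a 5.2-fold lower number from compound 2 to compound 3 (0.72 log units; beyond the scatter) and so removes a single carbon, yet moves the number clearly beyond the scatter. Less compound is needed without this methyl, so here a group is removed and the effect improves. Compound 3 also isolates a second site, because it differs from compound 1 in one place only: methoxy in place of 3-methyl-1H-pyrazol-4-yl gives an 11-fold higher number from compound 1 to compound 3 (1.03 log units; beyond the scatter) and shows that the pyrazole-bearing compound 1 needs much less compound than its methoxy counterpart.

The compounds shown leave open whether hydrogen is uniquely favoured at the carbon ortho to the methoxy group, or whether a fluorine atom, a chlorine atom, a hydroxyl or an ethyl group there would give a number closer to that of compound 3 or to that of compound 2. No measurement shown here gives a reason for either step.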